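The compounds below may be only part of what the source reports. "The series", "measured", "known", "first", "only" and "open" are said of these compounds alone.

Compound 3 `CS(=O)(=O)c1cnc(O[C@H]2CC[C@H](OC3CCN(C(=O)C4(C(F)(F)F)CC4)CC3)CC2)cn1` gives 1380 nM in a functional assay on isolated protein for agonist activity at Glucose-dependent insulinotropic receptor (Rattus norvegicus), read by HTRF and cAMP accumulation (a lower number here means that less compound is needed, a higher number that more compound is needed for the effect), the highest number among the three measured compounds; compound 1 `C[C@H](CF)OC(=O)N1CCC(O[C@H]2CC[C@H](Oc3cnc(S(C)(=O)=O)cn3)CC2)CC1` gives 317 nM and compound 2 `CS(=O)(=O)c1cnc(O[C@H]2CC[C@H](OC3CCN(C(=O)C4(C(F)(F)F)CCCC4)CC3)CC2)cn1` gives 108 nM. Compound 4 `CS(=O)(=O)c1cnc(O[C@H]2CC[C@H](OC3CCN(CC4(C(F)(F)F)CCCC4)CC3)CC2)cn1` differs from compound 3 by a group of 10 heavy atoms (7 carbon, 3 fluorine; one five-membered non-aromatic ring of carbon only) in place of a group of 9 heavy atoms (5 carbon, 1 oxygen, 3 fluorine; one three-membered non-aromatic ring of carbon only), on an amine nitrogen in a ring, so the carbonyl is lost and the ring is changed at once. Among the compounds with values here, the steps that bear on it are a 13-fold higher number from compound 2 to compound 3 (1.11 log units; beyond the scatter) and a 4.4-fold higher number from compound 1 to compound 3 (0.64 log units; beyond the scatter); both place the three-membered ring at the weak end of the series, and the five-membered ring gave the lowest number. Within the data shown here, no measured step covers loss of the carbonyl, so only part of the reversal is expected: the step of a 3.1-fold lower number from compound 3 to compound 4 (0.49 log units; beyond the scatter) is the estimate, with compound 4 expected at 450 nM and a range of 120 nM to 1800 nM.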

Compound 4, half-maximal effective concentration: 101 nM
Beside the measured number, compound 4's estimate is 4.5-fold (0.65 log units) above it; measured number below the stated range.
By their numbers in this assay, from the lowest: compounds 4 and 2 (each within the scatter of the next); then compound 1; then compound 3.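

In this assay, the loss of the carbonyl with the five-membered ring held gives a 1.1-fold lower number from compound 2 to compound 4 (0.03 log units; within the scatter), so at this amine nitrogen the carbonyl is not needed for the value of compound 2. The remaining steps, a 14-fold lower number from compound 3 to compound 4 (1.14 log units; beyond the scatter) and a 3.1-fold lower number from compound 1 to compound 4 (0.50 log units; beyond the scatter), therefore need no contribution from the carbonyl. No available evidence accounts for these results.

Still open, as far as these compounds go, is whether the three-membered ring without the carbonyl would keep the weak value of compound 3. A methyl or a nitrile in place of the trifluoromethyl also remains untested in the compounds shown.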